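A few compounds are considered here, and "the series" means these few. Any claim that something is new, unique, unknown or untested is made for them only; others in the source may bear on it.

Working notes on the series. Of the compounds shown here, three of the shared core have been measured in an ADME assay on Huh-7 cells (Homo sapiens) for cytotoxicity; a lower number here means a stronger inhibitor, a higher number a weaker inhibitor. Compound 1 `CN(c1cc2ncc(=O)[nH]c2cc1NC(=S)NC(=O)c1cccc(C(F)(F)F)c1)C1CCCCC1` gives 31500 nM. Compound 2 `CN(c1cc2ncc(=O)[nH]c2cc1NC(=S)NC(=O)c1ccco1)C1CCCCC1` gives 17300 nM. Compound 3 `CN(c1ccccc1)c1cc2ncc(=O)[nH]c2cc1Nc1nc(-c2ccccc2)cs1` gives 15900 nM. The numbers of compound 3 and compound 2 lie within the scatter of each other, and so do those of compound 3 and compound 1, so none of the three stands apart from the others. Going by the values given here, the only measured step is the change a 1.8-fold lower number from compound 1 to compound 2 (0.26 log units; within the scatter), which concerns a substituent on a carbonyl carbon.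

The next compound is compound 4 `CCCN(CCC)c1cc2ncc(=O)[nH]c2cc1Nc1nc(-c2ccccc2)cs1`. It differs from compound 3 by dipropylamino in place of methyl(phenyl)amino on an aromatic carbon. Among the compounds with values here, no measured pair in this set varies the amino substituent at that aromatic carbon, so no step bears directly on this change; the step from compound 1 to compound 2 sits at a different position and stayed within the scatter. The expectation is therefore a step of about a 1.0-fold higher number from compound 3 to compound 4 (0.00 log units; within the scatter) in this assay, with no direction beyond the scatter. For compound 4 the estimate in this assay is 16000 nM, with a range from 6000 nM to 45000 nM.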

Compound 4, half-maximal inhibitory concentration: 31600 nM
The estimate for compound 4 lay 2.0-fold (0.30 log units) below the measured number; the range from low to high includes it.
By their numbers in this assay, from the lowest: compounds 3, 2, 1 and 4 (each within the scatter of the next).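

The exchange of methyl(phenyl)amino for dipropylamino on this aromatic carbon gives a 2.0-fold higher number from compound 3 to compound 4 (0.30 log units; within the scatter) in this assay. Going by these compounds alone, this is the first reading at this position, as the earlier step lay on a carbonyl carbon. It shows that replacing a substituent carrying a six-membered aromatic ring of carbon only with one that has no ring leaves the number within the scatter, so no effect of this change can be claimed. Nothing available here bears on the size of this step.

The compounds shown leave open whether morpholine or dimethylamino at this aromatic carbon would produce a step beyond the scatter. They also leave open whether the same exchange would give a similar step in compound 1, whose other substituent differs from that of compound 3.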